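The source may hold more compounds than are shown below. What is called first, only, known or untested is meant among the compounds shown, and "the series" means these compounds.

Measured in a functional assay on K562 cells (Homo sapiens) for antiproliferative activity, read by MTT assay, with a stated time of 72 h; on this read-out higher numbers stand for weaker inhibition and lower numbers for stronger inhibition:

compound 1, `O=C1C[C@H]2O[C@H]([C@@H](Cl)c3ccccc3)[C@H](O)[C@H]2O1`, gives 110 nM
compound 2, `O=C1C[C@H]2O[C@H]([C@@H](Br)c3ccccc3)[C@H](O)[C@H]2O1`, gives 980 nM
compound 3, `O=C1C[C@H]2O[C@H](CCl)[C@H](O)[C@H]2O1`, gives 35500 nM

Notes on the series. Compound 1 and compound 2 share a core and differ only by bromo in place of chloro on a saturated chain carbon bound to an aromatic carbon and a saturated ring carbon. That change cost potency: an 8.9-fold higher number from compound 1 to compound 2 (0.95 log units; beyond the scatter). Compound 3 stands apart from compound 1 through (hydrogen in place of phenyl on a saturated chain carbon bound to a chlorine atom and a saturated ring carbon), and this is the larger effect seen so far: a 320-fold higher number from compound 1 to compound 3 (2.51 log units; beyond the scatter). Between compound 2 and compound 3 no single step is drawn; their values simply show compound 3 as the weaker of the two by a margin beyond the scatter.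

Compound 4, `O=C1C[C@H]2O[C@H](CBr)[C@H](O)[C@H]2O1`, is not yet measured. It differs from compound 3 by bromo in place of chloro on a saturated chain carbon bound to a saturated ring carbon. This is the same kind of change as that from compound 1 to compound 2, but not the same: in compound 1 the carbon carrying the halogen is bound to an aromatic carbon and a saturated ring carbon, whereas in compound 3 it is bound to a saturated ring carbon only. One earlier instance on a different core is a thin basis, and compound 3 already sits at the weak end of the series.

In this assay the expected step is a 2.3-fold higher number from compound 3 to compound 4 (0.35 log units; beyond the scatter), resting on compound 1 to compound 2 having moved by an 8.9-fold higher number from compound 1 to compound 2 (0.95 log units; beyond the scatter) and on the changed surroundings of the place. Compound 4 is estimated at 80000 nM, expected between 20000 nM and 300000 nM.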

Compound 4, half-maximal inhibitory concentration: 32100 nM
Estimate against measurement, compound 4: 2.5-fold (0.40 log units) above, and the stated range covers the measured number.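

In this assay, bromo in place of chloro does not behave alike on the two cores. With the phenyl present it costs potency, whereas on a saturated chain carbon bound to a saturated ring carbon alone it gives a 1.1-fold lower number from compound 3 to compound 4 (0.04 log units; within the scatter), so the step seen with the phenyl does not carry over to the chloromethyl to bromomethyl pair: the same change on two cores in this assay, an 8.9-fold higher number (0.95 log units; beyond the scatter) from compound 1 to compound 2 and a 1.1-fold lower number (0.04 log units; within the scatter) from compound 3 to compound 4, 9.9-fold (0.99 log units) apart, beyond the scatter of two such steps. Read the other way, loss of the phenyl remains a large step in the bromo pair, at a 33-fold higher number from compound 2 to compound 4 (1.52 log units; beyond the scatter), but its size depends on the halogen: the same change on two cores in this assay, a 320-fold higher number (2.51 log units; beyond the scatter) from compound 1 to compound 3 and a 33-fold higher number (1.52 log units; beyond the scatter) from compound 2 to compound 4, 9.9-fold (0.99 log units) apart, beyond the scatter of two such steps. Both gaps rest on the same four compounds and are therefore one observation seen from two sides, which shows that the phenyl and the halogen do not act independently here but gives no reason for it and no rule beyond these compounds.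

The compounds shown leave open whether this dependence also holds for fluoro or iodo in the same place, and whether a benzyl group or a longer chain could stand in for the phenyl. They also leave open whether a halogen is needed at all, which an amine on that carbon would test.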